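The compounds below may be only part of what the source reports. "The series", "measured", "known", "first", "only" and "open" are said of these compounds alone.

Measured so far in a functional assay on KB cells (Homo sapiens) for antiproliferative activity, read by MTT assay, with a stated time of 72 h; on this read-out higher numbers stand for weaker inhibition and lower numbers for stronger inhibition:
Compound 1 `COc1ccc(-c2sccc2-c2cc(OC)c(OC)c(OC)c2)cc1[N+](=O)[O-]` gives 10600 nM.
Compound 2 `COc1ccc(-c2sccc2-c2cc(OC)c(OC)c(OC)c2)cc1OCc1ccccc1` gives > 100000 nM, which is a limit of the assay and not a number.
Compound 3 `COc1ccc(-c2cc(C(=O)O)sc2-c2cc(OC)c(OC)c(OC)c2)cc1[N+](=O)[O-]` gives 43700 nM.

Compound 1 and compound 3 carry different cores; the difference between the two cores is not broken down here. Of the two numbers, compound 3 is the higher, and the gap is beyond the usual scatter.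

The change benzyloxy in place of nitro on an aromatic carbon made the step of an at least 9.4-fold higher number from compound 1 to compound 2 (0.97 log units; beyond the scatter), with compound 2 resting at the limit of > 100000 nM in this assay, at which 1 of the 3 values shown sits. Compound 4 `COc1ccc(-c2cc(C(=O)O)sc2-c2cc(OC)c(OC)c(OC)c2)cc1OCc1ccccc1` carries the same change on the core of compound 3: benzyloxy in place of nitro on an aromatic carbon. In this assay the expected step of a 6.9-fold higher number from compound 3 to compound 4 (0.84 log units; beyond the scatter) rests on the measured step of an at least 9.4-fold higher number from compound 1 to compound 2 (0.97 log units; beyond the scatter). Compound 4 is therefore expected to give about 300000 nM, between 100000 nM and 1000000 nM, and this assay may well report only a limit.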

Compound 4, half-maximal inhibitory concentration: > 100000 nM
Compound 4 ended at the assay's limit (the forecaster's own chance of this, stated with the estimate: 85%); the middle value is on the limit's open side.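

In this assay, benzyloxy in place of nitro also gave weaker inhibition on the core of compound 3, with an at least 2.2-fold higher number from compound 3 to compound 4 (0.35 log units; beyond the scatter). The direction of the change therefore carried over from one core to the other, but its size cannot be compared: the same change on two cores in this assay, an at least 9.4-fold higher number (0.97 log units; beyond the scatter) from compound 1 to compound 2 and an at least 2.2-fold higher number (0.35 log units; beyond the scatter) from compound 3 to compound 4; the limit leaves it open whether they differ. From the compounds shown here alone, compound 2 and compound 4 both rest at a limit of the assay and not at a number, so the true size of the loss on each core stays unknown: the limit of > 100000 nM in this assay, at which 2 of the 4 values shown sit.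

Left open is how an amine or a hydroxyl group in that same place would fare on these two cores. Also open, going by these compounds, is whether such a group would give the same step on both.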